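The source may hold more compounds than are shown below. What is called first, only, known or untested is meant among the compounds shown, and "the series" means these compounds.

Measured so far in a functional assay on BaF3 cells (Mus musculus) for inhibition, read by CCK-8 assay, with a stated time of 72 h; a lower number here means a stronger inhibitor of growth, a higher number a weaker inhibitor of growth:
Compound 1 `CC(=O)Nc1cc(Oc2ccc(NC(=O)Nc3ccc(CN4CCN(C)CC4)c(C(F)(F)F)c3)cc2)ncn1`: 50 nM
Compound 2 `CNCCN(C)c1cc(Oc2ccc(NC(=O)Nc3ccc(C)c(C(F)(F)F)c3)cc2)ncn1`: > 10000 nM

In this assay, compound 2 gives > 10000 nM, and this is a limit of the assay, not a number. For the measured compounds named here, compound 1 therefore holds the only exact value so far. Going by the values given here, no two measured compounds differ in just one place, so the data do not show the size of any single structural change.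

Compound 3 `Cc1ccc(NC(=O)Nc2ccc(Oc3cc(NCCO)ncn3)cc2)cc1C(F)(F)F` differs from compound 2 in one group: (2-hydroxyethyl)amino in place of methyl(2-(methylamino)ethyl)amino on an aromatic carbon. In words, (2-hydroxyethyl)amino stands in place of methyl(2-(methylamino)ethyl)amino on an aromatic carbon.

Among the compounds with values here, with no measured step to guide it, the expectation is loose. The one exact result, compound 1 at 50 nM, leaves room for a number well inside the range of this assay, but that compound also carries other groups. A modest move towards stronger growth inhibition is expected, and the estimated change is an at least 2.5-fold lower number from compound 2 to compound 3 (0.39 log units; beyond the scatter). A second result reported only as a limit would be no surprise. In this assay, the estimate for compound 3 is 4000 nM, with an expected range from 500 nM to 10000 nM.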

Compound 3, concentration for 50% growth inhibition: > 10000 nM
Compound 3 ended at the assay's limit; the forecaster's own chance of this, stated with the estimate: 40%; at least 2.5-fold (0.39 log units) between middle value and limit.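

Compound 2 and compound 3 both end at a limit in this assay and not at a number, so the step between them cannot be read: the limit of > 10000 nM in this assay, at which 2 of the 3 values shown sit. Still open, as far as these compounds go, is whether methyl(2-(methylamino)ethyl)amino or (2-hydroxyethyl)amino would give a readable number on a compound otherwise like compound 1.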